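The source may report more compounds than this note shows. Statements on the series, on what has been measured and on what is new or still open speak of the compounds shown alone.

Compound 3 `Cc1ccc(NC(=O)Nc2nn(-c3ccccc3)c(=O)c3ccccc23)cc1` stands second highest of the three compounds measured in an assay on CHO cells for displacement of a labelled ligand from adenosine receptor A1 (Homo sapiens), tested at 10 uM (a lower number here means less inhibition, a higher number more inhibition at the concentration tested (going by the name of the read-out)), where compound 3 gives 29%. Compound 2 `O=C(Nc1ccccc1)Nc1nn(-c2ccccc2)c(=O)c2ccccc12` gives 44% in this assay, and compound 1 `O=C(Nc1ccc(Cl)cc1)Nc1nn(-c2ccccc2)c(=O)c2ccccc12` gives 10%. The steps that touch compound 3 are a number 15 percentage points lower from compound 2 to compound 3 (beyond the scatter) and a number 19 percentage points higher from compound 1 to compound 3 (beyond the scatter), so exchanges at this aromatic carbon have moved the read-out by modest amounts in both directions. Compound 4 `COc1ccc(NC(=O)Nc2nn(-c3ccccc3)c(=O)c3ccccc23)cc1` differs from compound 3 by methoxy in place of methyl on an aromatic carbon. For the measured compounds named here, no measured pair exchanges these two groups, so those two modest steps are the only guides, and one expects a step of similar or smaller size in either direction, a number 1 percentage points higher from compound 3 to compound 4 (within the scatter). For compound 4 the estimate is 30%, with a range from 10% to 50%.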

Compound 4, a percentage reported as inhibition, at one concentration (the size of the read-out at that concentration, not a potency): 4%
Beside the measured number, compound 4's estimate is 26 percentage points above it; measured number outside the range, below it.
By their numbers in this assay, from the lowest: compounds 4 and 1 (each within the scatter of the next); then compound 3; then compound 2.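

In this assay methoxy does not behave like methyl at this position, with a number 25 percentage points lower from compound 3 to compound 4 (beyond the scatter), and the drop from the unsubstituted ring is a number 40 percentage points lower from compound 2 to compound 4 (beyond the scatter). Methoxy and chloro cannot be told apart here, with a number 6 percentage points lower from compound 1 to compound 4 (within the scatter), so among these four compounds hydrogen gives the highest number and methyl takes an intermediate place. Nothing at hand explains why these groups differ. As far as these compounds go, whether an amine, a hydroxyl group or fluoro on this carbon would also lower the number stays open. So does whether a longer chain such as ethoxy would follow methoxy.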